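Benzyl in place of acetyl on the aromatic nitrogen

The source may hold more compounds than are shown below. What is called first, only, known or untested is meant among the compounds shown, and "the series" means these compounds.

Measured so far in a functional assay on KB cells (Homo sapiens) for cytotoxicity (on this read-out higher numbers stand for weaker inhibition and lower numbers for stronger inhibition), are these compounds
compound 1 `COc1ccc(S(=O)(=O)N2CCc3cccc(NC(=O)Oc4ccccc4)c32)cc1` gives > 10000 nM as a limit of the assay
compound 2 `COc1ccc(S(=O)(=O)N2CCc3cccc(NC(=O)c4ccncc4)c32)cc1` gives 9.6 nM as a number
compound 3 `COc1ccc(S(=O)(=O)N2CCc3cccc(NC(C)=O)c32)cc1` gives 89 nM as a number

Of the two actual numbers, compound 3 holds the higher, and a 9.3-fold higher number from compound 2 to compound 3 (0.97 log units; beyond the scatter) is a modest step beyond the scatter. The next change leads to compound 4 `COc1ccc(S(=O)(=O)N2CCc3cccc(NCc4ccccc4)c32)cc1` with benzyl in place of acetyl on a nitrogen on an aromatic ring as the whole difference, which reads as acetamido to benzylamino.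

For the measured compounds named here, no measured step removes the carbonyl, so the evidence is indirect. Changes on the carbonyl carbon alone already gave large steps, with an at least 110-fold lower number from compound 1 to compound 3 (2.05 log units; beyond the scatter) as one example. Phenoxy in compound 1 and pyridin-4-yl in compound 2 both bring a ring, yet an at least 1000-fold lower number from compound 1 to compound 2 (3.01 log units; beyond the scatter) separates them, so a new ring does not settle the direction.

Going by the values given here, since every active compound so far keeps its carbonyl and the one change at that carbonyl away from acetyl with a higher number is large, a modest to large step towards weaker inhibition is expected in this assay with wide uncertainty. The expected change is a 4.5-fold higher number from compound 3 to compound 4 (0.65 log units; beyond the scatter) as a working figure. For compound 4 the estimated value is 400 nM with an expected range from 40 nM to 6000 nM in this read-out.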

Compound 4, half-maximal inhibitory concentration: > 10000 nM
Compound 4 gave a limit, no number; the forecaster's own chance of this, stated with the estimate: 20%; middle value at least 25-fold (1.39 log units) away from the limit.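

In this assay, exchanging acetyl for benzyl on the nitrogen on the aromatic ring gives an at least 110-fold higher number from compound 3 to compound 4 (2.05 log units; beyond the scatter), and the exchange of (pyridin-4-yl)carbonyl for benzyl at the same place gives an at least 1000-fold higher number from compound 2 to compound 4 (3.01 log units; beyond the scatter), so the first change shown that removes the carbonyl from this nitrogen is a large step towards weaker inhibition. Compound 4 carries a limit and not a number, so both steps give only a minimum size, and the step from compound 1 to compound 4 cannot be read: the limit of > 10000 nM in this assay, at which 2 of the 4 values shown sit. Among the compounds shown, actual numbers occur only with the two amides, compound 2 and compound 3, yet a carbonyl alone is not enough, as compound 1 keeps its carbonyl and also sits at a limit.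

The change to benzyl removes the carbonyl and brings in a ring in a single step, and the compounds shown do not separate these two parts. As far as these compounds go, a benzoyl group on this nitrogen, an ethyl group there and the free amine would each bear on that question, and they remain open here.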